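The source may report more compounds than this note shows. Statements on the series, on what has been measured and on what is new or still open speak of the compounds shown alone.

Compound 1 (`CCCCCCCCCCOc1cccc(O)c1C(=O)/C=C/c1cccc(O)c1`) and compound 2 (`CCCCCCCCCCOc1cccc(O)c1C(=O)/C=C/c1ccccc1O`) share one core and differ only in the hydroxyphenyl group on the chain. In an ADME assay on RAW264.7 cells (Mus musculus) for cytotoxicity, read by MTT assay (on this read-out lower numbers stand for stronger inhibition and higher numbers for weaker inhibition), compound 1 gives > 30000 nM as a limit, not a number. Compound 2 gives > 30000 nM as a limit too, so compound 2 stands on the limit of > 30000 nM in this assay, at which 2 of the 2 values shown sit, and has no exact value yet. Among the measured compounds shown here, the one measured step, a step that the two limits leave unreadable from compound 1 to compound 2 with 2-hydroxyphenyl in place of 3-hydroxyphenyl, offers no size to carry forward. Compound 3 (`CCCCCCCCCCOc1cccc(O)c1C(=O)/C=C/c1ccc(OC)cc1`) carries 4-methoxyphenyl in place of 2-hydroxyphenyl on a double-bonded chain carbon bound to a double-bonded chain carbon, a change counted as 4-methoxyphenyl in place of 2-hydroxyphenyl on a double-bonded chain carbon bound to a double-bonded chain carbon and still untested. With no readable step to lean on, no shift beyond the scatter is expected in this assay in either direction. The expected move is a number no higher from compound 2 to compound 3 (the limit leaves the size open) and no more. Compound 3 is estimated at 30000 nM with an expected range from 12000 nM to 60000 nM, and a limit rather than an exact value may well be expected.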

Compound 3, half-maximal inhibitory concentration: > 30000 nM
Compound 3: a limit, no number; the forecaster's own chance of this, stated with the estimate: 70%; the middle value lies on the limit itself.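

Compound 3 also gives a limit rather than a number, so no step among compound 1, compound 2 and compound 3 can be read in this assay: the limit of > 30000 nM in this assay, at which 3 of the 3 values shown sit.

The compounds shown leave open whether changing the group on the chain shifts this read-out at all, as none of them has an exact value.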